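Moving the Trifluoromethyl Group Around the Benzyl Ring

The compounds below may be only part of what the source reports. "The series", "measured", "known", "first", "only" and "open" are said of these compounds alone.

Measured so far:
compound 1 `COC(=O)C1=CN(C)C(=O)[C@@H]2C(CN3CCN(Cc4ccc(C(F)(F)F)cc4)CC3)=CC[C@H]12` gives 72.2%
compound 2 `COC(=O)C1=CN(C(C)C)C(=O)[C@@H]2C(CN3CCN(Cc4ccc(C(F)(F)F)cc4)CC3)=CC[C@H]12` gives 71.6%

Both were tested in a functional assay on Cortical neurone cells (Rattus norvegicus, strain Sprague-Dawley), read by MTT assay, with stated times of 24 h and 2 h, tested at 1 uM; on this read-out lower numbers stand for a weaker effect and higher numbers for a stronger effect at the one concentration tested. Compound 1 holds the higher of the two numbers, yet the step of a number 0.6 percentage points lower from compound 1 to compound 2 (within the scatter) lies within the scatter, so the two stand level. Compound 3 `COC(=O)C1=CN(C)C(=O)[C@@H]2C(CN3CCN(Cc4cccc(C(F)(F)F)c4)CC3)=CC[C@H]12` has not been measured; it differs from compound 1 by 3-(trifluoromethyl)phenyl in place of 4-(trifluoromethyl)phenyl on a saturated chain carbon bound to an amine nitrogen in a ring. Going by the values given here, the only measured step concerns the amide-type nitrogen and does not bear on this change, so nothing here speaks for a shift in either direction. The expected step of a number 6.2 percentage points lower from compound 1 to compound 3 (within the scatter) is therefore none beyond the scatter. Compound 3 is estimated at 66%, within a range from 45% to 82%.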

Compound 3, a percentage reported as activity, at one concentration (the size of the read-out at that concentration, not a potency): 72.5%
For compound 3 the middle estimate is 6.5 percentage points below the measured one; measured number inside the range.
By their numbers in this assay, from the lowest: compounds 2, 1 and 3 (each within the scatter of the next).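

Going by these compounds alone, this is the first change on the benzyl ring rather than on the amide-type nitrogen, and in this assay the step is a number 0.3 percentage points higher from compound 1 to compound 3 (within the scatter) on going from 4-(trifluoromethyl)benzyl to 3-(trifluoromethyl)benzyl. At this one concentration, then, the read-out does not separate these two placements of the trifluoromethyl group. Nothing available explains this result.

Still open, going by these compounds, is how a nitrile or methoxy group in place of trifluoromethyl would read, or a plain benzyl with no such group. The compounds shown also cannot tell whether the two placements would stay level at other concentrations.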